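The compounds below may be only part of what the source reports. "The series", "measured", "known", "first", "only" and "open" are said of these compounds alone.

The measured compounds:
compound 1, `O=C(O)C[C@@H]1CCCN1c1ccc(Oc2ccccc2)cc1`: > 16000 nM
compound 2, `O=C(O)C[C@@H]1CCCN1c1ccc(Oc2ccc(Cl)cc2Cl)cc1`: 3200 nM

Both were run in a functional assay on cells for agonist activity at Free fatty acid receptor 1 (Mus musculus), read by FLIPR and calcium flux, with a stated time of 100 s; on this read-out higher numbers stand for an effect only at larger amounts of compound and lower numbers for an effect already at smaller amounts. For compound 1 the recorded value is a limit of the assay, not a number, as stated in the limit of > 16000 nM in this assay, at which 1 of the 2 values shown sits. In this assay, among the measured compounds shown here, compound 2 gives 3200 nM, the only number among the two values. For the measured compounds named here, the one step between measured compounds runs from compound 1 to compound 2 and is an at least 5.0-fold lower number from compound 1 to compound 2 (0.69 log units; beyond the scatter).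

Compound 3 is `Cc1cccc(Oc2ccc(N3CCC[C@H]3CC(=O)O)cc2)c1`. It differs from compound 2 in one place: 3-methylphenyl in place of 2,4-dichlorophenyl on an oxygen on an aromatic ring. Going by the values given here, the only measured step that bears on this change is the one from compound 1 to compound 2, an at least 5.0-fold lower number from compound 1 to compound 2 (0.69 log units; beyond the scatter), in which 2,4-dichlorophenyl replaced phenyl at the same position. Compound 3 removes the 2,4-dichlorophenyl again but does not return to plain phenyl, so that step gives a direction and an outer bound rather than a size. A rise in the number is therefore expected for compound 3, smaller than the full step back towards compound 1, giving an expected step of a 2.8-fold higher number from compound 2 to compound 3 (0.45 log units; beyond the scatter). Compound 3 is estimated at 9000 nM, with a range from 3000 nM to 27000 nM.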

Compound 3, half-maximal effective concentration: 2400 nM
Compound 3: middle estimate off by 3.8-fold (0.57 log units), on the high side; measured number outside the range, below it.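

In this assay, among the compounds shown here, methyl in place of hydrogen on an aromatic carbon gives an at least 6.6-fold lower number from compound 1 to compound 3 (0.82 log units; beyond the scatter), so at this place on the oxygen a single small carbon group does what previously had been seen only with two chlorines. The exchange of 2,4-dichlorophenyl for 3-methylphenyl gives a 1.3-fold lower number from compound 2 to compound 3 (0.12 log units; within the scatter), which leaves compound 2 and compound 3 level with each other, and the earlier step can no longer be read as a matter of chlorine alone. Among the three compounds, then, both substituted rings give a measured number and only the plain phenyl of compound 1 does not, although two examples with different substituents at different places on the ring make a narrow basis for any wider rule.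

On these data alone, how large the effect of the methyl really is stays open, since compound 1 is recorded only as a limit of the assay: the limit of > 16000 nM in this assay, at which 1 of the 3 values shown sits. Also open is which single ring place carries the effect, and how a 4-methylphenyl, a 3-chlorophenyl, a 3-methoxyphenyl or a ring bearing an amine or a longer chain would read at the same oxygen.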